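Adding a trifluoroethoxy group to compound 2

The compounds below may be only part of what the source reports. "The series", "measured", "known", "first", "only" and "open" are said of these compounds alone.

Compound 1 `O=C(NCCC(c1ccc(F)cc1)c1ccc(F)cc1)c1cccnc1`: 0.2 h
Compound 2 `CS(=O)(=O)c1ccc(C(CCNC(=O)c2cccnc2)c2ccc(F)cc2)cc1`: 0.2 h

In an in vitro ADME assay on microsomes from liver (Rattus norvegicus) for metabolic stability, read by LC-MS, using NADPH (a lower number here means that the compound disappears faster, a higher number that the compound lasts longer), level with compound 1, compound 2 gives 0.2 h. Both compounds therefore sit at the same short half-life. Compound 3 `CS(=O)(=O)c1ccc(C(CCNC(=O)c2ccc(OCC(F)(F)F)nc2)c2ccc(F)cc2)cc1` differs from compound 2 in one place: 2,2,2-trifluoroethoxy in place of hydrogen on an aromatic carbon. The 2,2,2-trifluoroethoxy group takes the place of hydrogen on an aromatic carbon, next to the ring nitrogen. Within the data shown here, the only measured step, methylsulfonyl in place of fluoro on an aromatic carbon, gave no change at the digits printed from compound 1 to compound 2 (within the scatter). Among the measured compounds shown here, that step was made at a different place, so it is only a weak guide, and no measured step tests the new group. With so little evidence, no shift beyond the scatter is expected in this assay, and the estimated step is a 1.5-fold higher number from compound 2 to compound 3 (0.18 log units; within the scatter). Compound 3 is estimated at 0.3 h, with an expected range of 0.1 h to 1 h.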

Compound 3, half-life: 2.5 h
Compound 3: middle estimate off by 8.3-fold (0.92 log units), on the low side; the measured number lies above the stated range.
By their numbers in this assay, from the lowest: compounds 1 and 2 (each within the scatter of the next); then compound 3.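

In this assay 2,2,2-trifluoroethoxy in place of hydrogen on an aromatic carbon, next to the ring nitrogen, gives a 13-fold higher number from compound 2 to compound 3 (1.10 log units; beyond the scatter) in half-life. This shows that a change at this position can move the half-life well beyond the scatter, something compounds 1 and 2 could not show, since they carry the same hydrogen here and differ only at another place. Nothing shown here bears on what lies behind this step.

The compounds shown leave open whether this large step needs the 2,2,2-trifluoroethoxy group itself or whether a methoxy group, an amine or a single chlorine atom on the same carbon would also give it. They also leave open whether the group would give a step of this size on compound 1, which has fluoro where compound 2 has methylsulfonyl.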